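The source may hold more compounds than are shown below. What is called first, only, known or untested is meant among the compounds shown, and "the series" means these compounds.

Compound 1 `Nc1cc(N)c2nc(-c3ccccc3)c(Oc3ccc(Cl)c(Cl)c3)nc2c1` is placed in a functional assay on SN12C cells (Homo sapiens) for inhibition, read by sulforhodamine B assay, with a stated time of 48 h (on this read-out lower numbers stand for higher toxicity in this test and higher numbers for lower toxicity in this test), only by a limit: compound 1 gives < 100000 nM, which is a limit of the assay and not a measured number. Compound 2 `CCOC(=O)[C@H](CCC(=O)O)NC(=O)c1ccc(CNc2nc3cc(N)cc(N)c3nc2-c2ccccc2)cc1` likewise gives < 100000 nM, again a limit of the assay. Going by the values given here, compound 3 `COc1cc(CNc2nc3cc(N)cc(N)c3nc2-c2ccccc2)cc(OC)c1OC` is the one compound of the three with a number, giving 32400 nM in this assay. Two of the three values thus sit at the limit of < 100000 nM in this assay, at which 2 of the 3 values shown sit, so compound 1 cannot be ordered against compound 2 or compound 3 on what is known.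

Compound 4 `COc1ccc(Sc2nc3cc(N)cc(N)c3nc2-c2ccccc2)cc1` differs from compound 1 by (4-methoxyphenyl)sulfanyl in place of 3,4-dichlorophenoxy on an aromatic carbon. Among the compounds with values here, no pair of measured compounds shows this change, and compound 1 itself has no number, so the size of the step has no anchor among the measured compounds. The expected step is a step that the limit leaves unreadable from compound 1 to compound 4, which is read as nothing beyond the scatter. Compound 4 is estimated at 30000 nM, with a range from 8000 nM to 100000 nM, and with a real chance that this assay again reports only a limit.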

Compound 4, concentration lethal to 50% of the cells: 87100 nM
The estimate for compound 4 lay 2.9-fold (0.46 log units) below the measured number, and the stated range covers the measured number.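

Going by these compounds alone, compound 1 is known only by a limit of the assay while compound 4 has a number, and no step between the two can be read. The compounds shown leave open how far (4-methoxyphenyl)sulfanyl in place of 3,4-dichlorophenoxy shifts the read-out: no pair with two numbers shows this change.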